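The source may hold more compounds than are shown below. What is called first, only, known or untested is meant among the compounds shown, and "the series" means these compounds.

In a functional assay on A549 cells (Homo sapiens) for cytotoxicity, read by MTT assay, with a stated time of 72 h (on this read-out higher numbers stand for weaker inhibition and lower numbers for stronger inhibition), compound 1 (`CC1CCN(Cc2ccc3nc(NC(=O)N/N=C/c4cn(Cc5cccc(Cl)c5)c5ccccc45)sc3c2)CC1`) gives 2810 nM and compound 2 (`CC1CCN(Cc2ccc3nc(NC(=O)N/N=C/c4cn(Cc5ccccc5Cl)c5ccccc45)sc3c2)CC1`) gives 3330 nM. Among the compounds with values here, these are the only two numbers so far, and they lie within the scatter of each other, so compound 2 stands level with compound 1. Compound 3 (`CC1CCN(Cc2ccc3nc(NC(=O)N/N=C/c4cn(Cc5ccc(Cl)cc5)c5ccccc45)sc3c2)CC1`) keeps the shared core and differs from compound 2 in one place: 4-chlorophenyl in place of 2-chlorophenyl on a saturated chain carbon bound to an aromatic nitrogen. In words, 4-chlorophenyl takes the place of 2-chlorophenyl on a saturated chain carbon bound to an aromatic nitrogen, so the two compounds have the same atoms, joined differently. Within the data shown here, one measured step bears on this change, an exchange of chlorophenyl groups at the same place: a 1.2-fold higher number from compound 1 to compound 2 (0.07 log units; within the scatter). That step stays within the scatter, but it is a single step, and no number yet exists for the 4-chlorophenyl group. No shift beyond the scatter is therefore expected in this assay, in either direction. The expected step is a 1.1-fold lower number from compound 2 to compound 3 (0.05 log units; within the scatter). Compound 3 is estimated at 3000 nM, with an expected range from 1300 nM to 7000 nM.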

Compound 3, half-maximal inhibitory concentration: 2030 nM
Compound 3: the middle estimate sits 1.5-fold (0.17 log units) above what was measured; low and high end bracket the measured number.
By their numbers in this assay, from the lowest: compounds 3, 1 and 2 (each within the scatter of the next).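

In this assay the new steps read a 1.6-fold lower number from compound 2 to compound 3 (0.21 log units; within the scatter) and a 1.4-fold lower number from compound 1 to compound 3 (0.14 log units; within the scatter) and so stay within the scatter, as the earlier exchange did. The earlier compounds shown here could speak only for the 2-chlorophenyl and 3-chlorophenyl groups, whereas compounds 1, 2 and 3 now cover all three chlorophenyl groups on a saturated chain carbon bound to an aromatic nitrogen, and none of the three exchanges among them gives a step beyond the scatter. Moving from one of these groups to another, with the same atoms joined differently, therefore gives no separation among these three compounds on this read-out, and nothing at hand offers an explanation for the numbers.

From the compounds shown here alone, all three compounds carry chlorine on the phenyl ring, so what remains open is whether a plain phenyl group, or a phenyl group bearing fluorine, methoxy or nitrile in place of chlorine, would stand level with them at this place. Going by these compounds, it is equally open whether a longer chain, such as 2-phenylethyl in place of the chlorobenzyl group, or an amine or a carboxylic acid on that ring, would give a step beyond the scatter.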